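Dimethylamino for nitro on two related P2X7 antagonist cores

The source may hold more compounds than are shown below. What is called first, only, known or untested is meant among the compounds shown, and "the series" means these compounds.

Measured compounds:
compound 1, `O=C(c1ccc([N+](=O)[O-])cc1)N1CCC(n2cncc2-c2ccc(OS(=O)(=O)c3cccc4cnccc34)cc2)CC1`, 8.29 nM
compound 2, `CN(C)c1ccc(C(=O)N2CCC(n3cncc3-c3ccc(OS(=O)(=O)c4cccc5cnccc45)cc3)CC2)cc1`, 2.19 nM
compound 3, `CNC(=O)c1cccc(S(=O)(=O)Oc2ccc(-c3cncn3C3CCN(C(=O)c4ccc([N+](=O)[O-])cc4)CC3)cc2)c1`, 26 nM

In an assay on THP-1 cells for antagonist activity at P2X purinoceptor 7 (Homo sapiens), read by ELISA, with a stated time of 30 min (on this read-out lower numbers stand for stronger inhibition and higher numbers for weaker inhibition), compound 1 gives 8.29 nM, compound 2 gives 2.19 nM and compound 3 gives 26 nM. Compound 2 differs from compound 1 by dimethylamino in place of nitro on an aromatic carbon, and this change made a 3.8-fold lower number from compound 1 to compound 2 (0.58 log units; beyond the scatter). Compound 3 differs from compound 1 in its core, by 3-(methylcarbamoyl)phenyl in place of isoquinolin-5-yl on a sulfonyl sulfur, giving a 3.1-fold higher number from compound 1 to compound 3 (0.50 log units; beyond the scatter); among the three measured compounds compound 3 has the highest number in this assay.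

Compound 4, `CNC(=O)c1cccc(S(=O)(=O)Oc2ccc(-c3cncn3C3CCN(C(=O)c4ccc(N(C)C)cc4)CC3)cc2)c1`, has not yet been measured. It differs from compound 3 by dimethylamino in place of nitro on an aromatic carbon, and the place of this change is worded exactly as for the pair of compound 1 and compound 2, so it is the same change made on the core of compound 3. The step from compound 3 to compound 4 in this assay is expected to be a 3.7-fold lower number from compound 3 to compound 4 (0.57 log units; beyond the scatter), resting on the step of a 3.8-fold lower number from compound 1 to compound 2 (0.58 log units; beyond the scatter) seen on the other core. Compound 4 is therefore estimated at 7 nM, between 3 nM and 18 nM.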

Compound 4, half-maximal inhibitory concentration: 22 nM
Beside the measured number, compound 4's estimate is 3.1-fold (0.50 log units) below it; the whole stated range lies below it.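

In this assay, among these compounds, dimethylamino in place of nitro on the core of compound 3 gives a 1.2-fold lower number from compound 3 to compound 4 (0.07 log units; within the scatter), so the clear step seen on the core of compound 1 does not carry over, and the two steps differ: the same change on two cores in this assay, a 3.8-fold lower number (0.58 log units; beyond the scatter) from compound 1 to compound 2 and a 1.2-fold lower number (0.07 log units; within the scatter) from compound 3 to compound 4, 3.2-fold (0.51 log units) apart, beyond the scatter of two such steps Read the other way, 3-(methylcarbamoyl)phenyl in place of isoquinolin-5-yl on the sulfonyl sulfur gives a 10-fold higher number from compound 2 to compound 4 (1.00 log units; beyond the scatter) when dimethylamino is present, a larger step than with nitro, so in these four compounds the two changes do not add independently: the same change on two cores in this assay, a 3.1-fold higher number (0.50 log units; beyond the scatter) from compound 1 to compound 3 and a 10-fold higher number (1.00 log units; beyond the scatter) from compound 2 to compound 4, 3.2-fold (0.51 log units) apart, beyond the scatter of two such steps This shows that the step from nitro to dimethylamino depends on the core here, but each core supplies only one pair, and it does not show why the steps differ or what would happen on a third core.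

The compounds shown leave open whether a primary amine or a methoxy group in place of nitro would also depend on the core. They also leave open whether a carboxylic acid in place of the methylcarbamoyl group would change the picture.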